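The source may hold more compounds than are shown below. What is called first, only, known or untested is meant among the compounds shown, and "the series" means these compounds.

Series notes. Compound 1 `O=C(CCCCCCc1ccccc1)c1nncs1` carries the shared core with a hydrogen on the aromatic carbon. In an assay on HEK-293T cells for inhibition of diacylglycerol lipase-alpha (Homo sapiens), read by colorimetric assay (on this read-out higher numbers stand for weaker inhibition and lower numbers for stronger inhibition), compound 1 gives > 10000 nM, a limit of the assay and not a number. Compound 2 `O=C(CCCCCCc1ccccc1)c1nnc(-c2ccco2)s1` differs from compound 1 by furan-2-yl in place of hydrogen on an aromatic carbon. In this assay compound 2 gives > 10000 nM, again a limit. The step that the two limits leave unreadable from compound 1 to compound 2 rests on (the limit of > 10000 nM in this assay, at which 3 of the 3 values shown sit). Compound 3 `O=C(CCCCCCc1ccccc1)c1ncno1` differs from compound 1 in the core, by 1,2,4-oxadiazol-5-yl in place of 1,3,4-thiadiazol-2-yl on a carbonyl carbon. In this assay compound 3 gives > 10000 nM, a limit. The step that the two limits leave unreadable from compound 1 to compound 3 likewise rests on (the limit of > 10000 nM in this assay, at which 3 of the 3 values shown sit).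

Compound 4 `O=C(CCCCCCc1ccccc1)c1nc(-c2ccco2)no1` is not yet measured in this assay. It differs from compound 3 by furan-2-yl in place of hydrogen on an aromatic carbon. This is the same kind of change as from compound 1 to compound 2, though the place differs: there the group enters on a five-membered aromatic ring with 2 nitrogen and 1 sulfur, next to the ring nitrogen and next to the ring sulfur; here on a five-membered aromatic ring with 2 nitrogen and 1 oxygen, between two ring nitrogen atoms. Since compound 3 gives only the limit > 10000 nM, the step from compound 3 to compound 4 is expected near a step that the limit leaves unreadable from compound 3 to compound 4, and compound 4 is expected around 20000 nM, between 5000 nM and 100000 nM, most likely reported as a limit.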

Compound 4, half-maximal inhibitory concentration: 933 nM
Beside the measured number, compound 4's estimate is 21-fold (1.33 log units) above it; measured number outside the range, below it.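

In this assay, furan-2-yl in place of hydrogen on an aromatic carbon of the core of compound 3 gives an at least 10-fold lower number from compound 3 to compound 4 (1.03 log units; beyond the scatter), so on this core the change clearly lowers the number. On the core of compound 1 the same kind of change leads to compound 2, which gives > 10000 nM, a limit of the assay and not a number. The steps from compound 1 to compound 2 and from compound 1 to compound 3 cannot be read, so the result on the core of compound 3 is neither confirmed nor contradicted on the core of compound 1, and the change is not shown to carry from one core to the other: the limit of > 10000 nM in this assay, at which 3 of the 4 values shown sit.

Still open, from the compounds shown here alone, is whether another group on the aromatic carbon between two ring nitrogen atoms, such as phenyl, an amine or a carboxylic acid, would do the same as furan-2-yl on the core of compound 3. Also open, going by these compounds, is how a longer chain between the carbonyl and the phenyl ring would read on compound 4.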